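Mirror-image pair in the antiproliferative assay

The source may hold more compounds than are shown below. What is called first, only, known or untested is meant among the compounds shown, and "the series" means these compounds.

Measured so far:
Compound 1 `CC(C)(C)OC(=O)NCCC[C@@H]1N=C2C[C@@H]3C[C@@H](C3(C)C)[C@]2(C)OC1=O` gives > 1200000 nM in an ADME assay on MCF-10A cells (Homo sapiens) for antiproliferative activity, read by sulforhodamine B assay, with a stated time of 48 h (a lower number here means a stronger inhibitor, a higher number a weaker inhibitor), a limit of the assay and not a number.
Compound 2 `CC(C)(C)OC(=O)n1cnc(C[C@H]2N=C3C[C@H]4C[C@H](C4(C)C)[C@@]3(C)OC2=O)c1` gives > 1300000 nM in this assay, also a limit of the assay.
Compound 3 `CC1(C)[C@@H]2CC3=N[C@@H](CCC(=O)O)C(=O)O[C@@]3(C)[C@H]1C2` gives > 1200000 nM, again a limit of the assay.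

Compound 1 therefore stands at the limit of > 1200000 nM in this assay, at which 2 of the 3 values shown sit, shared with compound 3. Compound 2 sits at the limit of > 1300000 nM in this assay, at which 1 of the 3 values shown sits. For the measured compounds named here, none of the three gives a number, so no measured step between them exists, and the series offers no scale for the size of any change within the shared core of compound 1.

Compound 4 `CC(C)(C)OC(=O)NCCC[C@H]1N=C2C[C@H]3C[C@H](C3(C)C)[C@@]2(C)OC1=O` is not yet measured. It differs from compound 1 by the two compounds have the same atoms and bonds and differ only in configuration as drawn: 4 of 4 stereo elements differ (all stereocentres are inverted: mirror images); a stereocentre at a saturated ring carbon is drawn S in compound 1 and R in compound 4; a stereocentre at a saturated ring carbon is drawn S in compound 1 and R in compound 4; a stereocentre at a saturated ring carbon is drawn S in compound 1 and R in compound 4; a stereocentre at a saturated ring carbon is drawn S in compound 1 and R in compound 4. With every measured value at a limit, the only expectation that the data support for this assay is no step beyond the scatter: compound 4 is expected to land at the same limit as compound 1, with the step of a number no higher from compound 1 to compound 4 (the limit leaves the size open) estimated as none beyond the scatter. The estimate for compound 4 is 1200000 nM, with a range from 300000 nM to 5000000 nM, most probably reported again only as a limit.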

Compound 4, half-maximal inhibitory concentration: > 1500000 nM
Compound 4 ended at the assay's limit (the forecaster's own chance of this, stated with the estimate: 85%); middle value at least 1.2-fold (0.09 log units) from the limit.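

In this assay compound 4 gives > 1500000 nM, a limit of the assay. Compound 1 gives > 1200000 nM, also a limit, so no step can be read between these mirror images, compound 1 and compound 4. The compounds shown leave open whether inverting all stereocentres changes the result in this assay at all.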